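Methoxy for methyl in a series at the assay limit

A few compounds are considered here, and "the series" means these few. Any claim that something is new, unique, unknown or untested is made for them only; others in the source may bear on it.

Measured so far:
- Compound 1, `COc1ccc2[nH]c(=O)c(-c3nc4cc(C)c(C)cc4[nH]3)cc2c1`. In a functional assay on SK-OV-3 cells (Homo sapiens) for cytotoxicity, read by MTT assay, with a stated time of 48 h (a lower number here means a stronger inhibitor, a higher number a weaker inhibitor), compound 1 gives > 100000 nM, which is a limit of the assay rather than a number.
- Compound 2, `Cc1ccc2[nH]c(=O)c(-c3nc4cc(C)c(C)cc4[nH]3)cc2c1`. In this assay compound 2 gives > 100000 nM, again a limit of the assay.
- Compound 3, `Cc1ccc2[nH]c(=O)c(-c3nc4cc(Br)ccc4[nH]3)cc2c1`. In this assay compound 3 gives > 100000 nM, also a limit of the assay.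

All three compounds share a core, and the difference between the core of compound 2 and the core of compound 3 is not broken down here. Compound 1 and compound 2 differ by one change, (methoxy in place of methyl on an aromatic carbon), and the resulting step, a step that the two limits leave unreadable from compound 2 to compound 1, cannot be read, since both values are limits. The whole picture so far is summed up by the limit of > 100000 nM in this assay, at which 3 of the 3 values shown sit.

Compound 4, `COc1ccc2[nH]c(=O)c(-c3nc4cc(Br)ccc4[nH]3)cc2c1`, has not yet been measured. It differs from compound 3 by methoxy in place of methyl on an aromatic carbon, the same change that separates compound 2 from compound 1, made at a place described in the same words.

The expected step from compound 3 to compound 4 is a step that the limit leaves unreadable from compound 3 to compound 4, that is, no readable change, an expectation that rests on the limit of > 100000 nM in this assay, at which 3 of the 3 values shown sit, because every measured value, including the pair that already carries this change, sits there. Compound 4 is therefore expected to give about 150000 nM in this assay, most likely reported as a limit again.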

Compound 4, half-maximal inhibitory concentration: > 100000 nM
Compound 4: no number, only a limit; the forecaster's own chance of this, stated with the estimate: 85%; the middle value does not contradict the limit.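

The values of compound 3 and compound 4 in this assay are both limits of the assay rather than numbers, so swapping methyl for methoxy between them gives no step that can be read: the limit of > 100000 nM in this assay, at which 4 of the 4 values shown sit.

The compounds shown leave open whether methoxy and methyl differ at all in this cytotoxicity read-out, and what change to the shared core, if any, would give a measurable value.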